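From benzoyl to methyl(phenyl)carbamoyl on the shared core

This account rests on a few compounds, and the source may have more. Where it says the series, first, only, none or still open, it means among the compounds named here.

Measured in a functional assay on MKN-45 cells (Homo sapiens) for cytotoxicity (a lower number here means a stronger inhibitor, a higher number a weaker inhibitor), so far
compound 1 `COc1ccc(S(=O)(=O)N2CCc3cccc(NC(=O)c4ccncc4)c32)cc1` gives 8.8 nM
compound 2 `COc1ccc(S(=O)(=O)N2CCc3cccc(NCc4ccccc4)c32)cc1` gives > 10000 nM as a limit of the assay
compound 3 `COc1ccc(S(=O)(=O)N2CCc3cccc(NC(=O)c4ccccc4)c32)cc1` gives 250 nM

Compound 3 at 250 nM has the higher of the two exact numbers, and the gap is large, with a 28-fold higher number from compound 1 to compound 3 (1.45 log units; beyond the scatter) on record. Compound 4 `COc1ccc(S(=O)(=O)N2CCc3cccc(NC(=O)N(C)c4ccccc4)c32)cc1` has not yet been measured. It carries methyl(phenyl)amino in place of phenyl on a carbonyl carbon, so benzoyl becomes methyl(phenyl)carbamoyl, and the count reads methyl(phenyl)amino in place of phenyl on a carbonyl carbon for this change.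

Going by the values given here, no measured compound carries the entering group, so no step matches this change exactly. Two steps come closest. One is a 28-fold higher number from compound 1 to compound 3 (1.45 log units; beyond the scatter) at the same carbonyl carbon. The other is an at least 40-fold lower number from compound 2 to compound 3 (1.60 log units; beyond the scatter) on the same nitrogen, and it rests on the limit of compound 2. Both are large, so a step beyond the scatter is expected here too. The direction is only a judgement, and a moderately higher number is the expectation. The expected change is a 3.2-fold higher number from compound 3 to compound 4 (0.51 log units; beyond the scatter) on this reading. Compound 4 is estimated at 800 nM with an expected range from 100 nM to 6000 nM in this assay when it is measured.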

Compound 4, half-maximal inhibitory concentration: > 10000 nM
Compound 4: a limit, no number; the forecaster's own chance of this, stated with the estimate: 15%; at least 12-fold (1.09 log units) between middle value and limit.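

In this assay compound 4 gives > 10000 nM, which is a limit of the assay and not a number. Placing methyl(phenyl)amino on the carbonyl carbon in place of phenyl gives an at least 40-fold higher number from compound 3 to compound 4 (1.60 log units; beyond the scatter), and placing it there in place of pyridin-4-yl gives an at least 1100-fold higher number from compound 1 to compound 4 (3.05 log units; beyond the scatter). Among the earlier compounds only compound 2, which has benzyl on the nitrogen and no carbonyl there, sat at the limit, whereas this result shows that keeping the carbonyl does not by itself preserve activity, since among the four compounds shown the group on the carbonyl carbon separates compound 1, compound 3 and compound 4.

Going by these compounds, the step from compound 2 to compound 4 cannot be read, because both values are limits: the limit of > 10000 nM in this assay, at which 2 of the 4 values shown sit. It remains open whether the loss goes with the methyl or with the added nitrogen, which phenylamino on the same carbonyl carbon would separate, and how a smaller group such as dimethylamino or a ring amine such as morpholin-4-yl would read there.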